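The source may hold more compounds than are shown below. What is called first, only, known or untested is meant among the compounds shown, and "the series" means these compounds.

In an assay on HEK293 cells for positive allosteric modulation of metabotropic glutamate receptor 5 (Homo sapiens), read by FLIPR, with a stated time of 1 h (on this read-out higher numbers stand for an effect only at larger amounts of compound and lower numbers for an effect already at smaller amounts), three compounds have been measured so far. Compound 1 `COc1ccccc1C#Cc1nc2c(s1)C(=O)NCC2` gives only a limit, > 10000 nM. Compound 2 `CN1CCc2nc(C#Cc3cccc(F)c3)sc2C1` likewise gives only a limit, > 10000 nM. For the measured compounds named here, compound 3 `O=C(C1CC12CCC2)N1CCc2nc(C#Cc3ccccc3)sc2C1` gives 3.9 nM, the only true number among the three. The two other values sit at the limit of > 10000 nM in this assay, at which 2 of the 3 values shown sit. Compound 4 `O=C(C1CCOCC1)N1CCc2nc(C#Cc3ccccc3)sc2C1` has not yet been measured. It differs from compound 3 in one place: a group of 6 heavy atoms (5 carbon, 1 oxygen; one six-membered non-aromatic ring with 1 hetero atom) in place of a group of 6 heavy atoms (6 carbon; one three-membered non-aromatic ring of carbon only, one four-membered non-aromatic ring of carbon only), on a carbonyl carbon. Going by the values given here, no pair of measured compounds differs in just one place, so no measured step guides this change. In this assay a modest weakening is expected, of a size that may still stay within the usual scatter. The expected step is a 3.1-fold higher number from compound 3 to compound 4 (0.49 log units; beyond the scatter). Compound 4 is therefore estimated at 12 nM, with a range from 3 nM to 60 nM.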

Compound 4, half-maximal effective concentration: 290 nM
The estimate for compound 4 lay 24-fold (1.38 log units) below the measured number, and the stated range ends below it.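

In this assay, the group on the carbonyl carbon proves highly sensitive: oxan-4-yl in place of the all-carbon group with its three-membered and four-membered rings gives a 74-fold higher number from compound 3 to compound 4 (1.87 log units; beyond the scatter), the only one-place comparison shown. Both groups hold 6 heavy atoms, so the same count does not guarantee a similar number at this position. Nothing measured here accounts for the size of this step.

On these data alone, it remains open where a cyclohexyl group on the same carbonyl carbon would fall, which would help separate the ring oxygen from the change in ring shape. As far as these compounds go, a piperidin-4-yl group, with a ring nitrogen in place of that oxygen, is equally open.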